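The source may hold more compounds than are shown below. What is called first, only, known or untested is meant among the compounds shown, and "the series" means these compounds.

Measured compounds:
compound 1 `Cc1ccc(C2=NNC(c3cn(-c4ccccc4)nc3-c3ccc(Cl)c(Cl)c3)C2)cc1` — 56.5%
compound 2 `CC(=O)N1N=C(c2ccc(Cl)cc2)CC1c1cn(-c2ccccc2)nc1-c1ccc(Cl)c(Cl)c1` — 57.3%

In a functional assay on the whole organism (strain Wistar) for inhibition, with Rattus norvegicus as the target, read by paw edema, with stated times of 30 min and 60 min, at a dose of 50 mg/kg by the oral route (on this read-out lower numbers stand for less inhibition and higher numbers for more inhibition at the one dose given (going by the name of the read-out)), compound 2 gives the highest of the two numbers, though compound 1 stands only a little below it, within the scatter, so the two compounds read as level. Compound 3 `Clc1ccc(C2=NNC(c3cn(-c4ccccc4)nc3-c3ccc(Cl)c(Cl)c3)C2)cc1` awaits measurement in this assay. Relative to compound 2 its difference is hydrogen in place of acetyl on an amine nitrogen in a ring. Among the measured compounds shown here, no pair of measured compounds differs by this change alone, so no measured step for it exists. What the data show is that compound 1, which carries hydrogen on that ring nitrogen, and compound 2, which carries acetyl there, give values within the scatter of each other. On that basis the expected step is a number 1.3 percentage points lower from compound 2 to compound 3 (within the scatter), none beyond the scatter. Compound 3 is therefore estimated at 56%, within the range 44% to 68%.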

Compound 3, a percentage reported as inhibition, in the whole organism at one dose (the size of the read-out at that dose, not a potency): 45.8%
Beside the measured number, compound 3's estimate is 10.2 percentage points above it, and the stated range covers the measured number.
By their numbers in this assay, from the lowest: compound 3; then compounds 1 and 2 (each within the scatter of the next).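

Compounds 1 and 2 differ in two places at once, so they could not separate these changes; with the 4-chlorophenyl group held constant, hydrogen in place of acetyl on the amine nitrogen in a ring gives a number 11.5 percentage points lower from compound 2 to compound 3 (beyond the scatter) in this assay. With hydrogen on that nitrogen in both compounds, chloro in place of methyl on an aromatic carbon gives a number 10.7 percentage points lower from compound 1 to compound 3 (beyond the scatter), so in this small set the read-out responds to each of the two places taken alone. Nothing on hand explains either step.

The compounds shown leave open whether acetyl on that nitrogen gives a step of similar size when methyl takes the place of chloro on the aromatic carbon. They also leave open how a longer acyl chain such as butanoyl on the nitrogen, or a methoxy group on the aromatic carbon, would read in this assay.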